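A few compounds are considered here, and "the series" means these few. Any claim that something is new, unique, unknown or untested is made for them only; others in the source may bear on it.

In a functional assay on SW480 cells (Homo sapiens) for antiproliferative activity, read by MTT assay, with a stated time of 48 h (a higher number here means a weaker inhibitor, a lower number a stronger inhibitor), compound 1 `CCCC(CCO)n1cnc2c(Cl)ncnc21` gives > 50000 nM, which is a limit of the assay and not a number. On the same core with a longer chain, compound 2 `CCCCCCC(CCO)n1cnc2c(Cl)ncnc21` gives 16700 nM and compound 3 `CCCCCCCC(CCO)n1cnc2c(Cl)ncnc21` gives 3630 nM, the lower of the two true numbers in this assay. Among the measured compounds shown here, compound 3 is therefore the strongest inhibitor of the series so far.

Compound 4 `CCCCCCCCCC(CCO)n1cnc2c(Cl)ncnc21` extends the chain once more, and its difference from compound 3 is ethyl in place of hydrogen on a saturated chain carbon, eight bonds along the chain from an aromatic nitrogen. For the measured compounds named here, three measured steps bear on this change, and each is a chain extension. The first is an at least 2.9-fold lower number from compound 1 to compound 2 (0.47 log units; beyond the scatter), and the second is an at least 13-fold lower number from compound 1 to compound 3 (1.13 log units; beyond the scatter). The closest guide is the most recent extension, a 4.6-fold lower number from compound 2 to compound 3 (0.66 log units; beyond the scatter). None of the three compounds goes against the fall in the number as the chain grows. However, three compounds cannot show whether that fall continues, and it may slow or stop at a longer chain. A modest further drop therefore seems the most reasonable expectation, smaller than a simple extrapolation would give. The expected change is a 2.4-fold lower number from compound 3 to compound 4 (0.38 log units; beyond the scatter). Compound 4 is estimated to give about 1500 nM, with an expected range of 500 nM to 5000 nM.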

Compound 4, half-maximal inhibitory concentration: 1150 nM
For compound 4 the middle estimate is 1.3-fold (0.12 log units) above the measured one; measured number inside the range.
By their numbers in this assay, from the lowest: compound 4; then compound 3; then compound 2. At a limit, above all of these: compound 1.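

Lengthening the chain once more still lowers the number in this assay: ethyl in place of hydrogen on a saturated chain carbon, eight bonds along the chain from an aromatic nitrogen, gives a 3.2-fold lower number from compound 3 to compound 4 (0.50 log units; beyond the scatter), so the fall seen up to compound 3 had not stopped at that length. Taken together, the last two extensions amount to a 15-fold lower number from compound 2 to compound 4 (1.16 log units; beyond the scatter), and no compound shown goes against the fall in the number as the chain grows. Compound 1 stands at a limit and not at a true number, so the whole run can be stated only as a bound, an at least 43-fold lower number from compound 1 to compound 4 (1.63 log units; beyond the scatter), and its real size stays unknown: the limit of > 50000 nM in this assay, at which 1 of the 4 values shown sits.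

As far as these compounds go, whether a longer chain than that of compound 4 would continue this fall, slow it or reverse it remains open. Also open, from the compounds shown here alone, is what an amine or a carboxylic acid in place of the hydroxyl would do to the number, and whether the same order of compounds would hold on cells other than those of this single test.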